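Trifluoromethyl in Place of Fluoro: What to Expect

The source may report more compounds than this note shows. Statements on the series, on what has been measured and on what is new or still open speak of the compounds shown alone.

Compound 1, `CCOC(=O)c1cnc(-c2ccc(OC)cc2)nc1NN1C(=O)C=C(C)C1=O`, gives 900 nM in a functional assay on Jurkat cells for inhibition of nuclear factor NF-kappa-B complex (Homo sapiens); on this read-out higher numbers stand for weaker inhibition and lower numbers for stronger inhibition.
Compound 2, `CCOC(=O)c1cnc(-c2ccc(F)cc2)nc1NN1C(=O)C=C(C)C1=O`, gives 700 nM in this assay.

Compound 2 stands beside compound 1 on these two numbers; the gap between them, a 1.3-fold lower number from compound 1 to compound 2 (0.11 log units; within the scatter), is within the scatter, so the two cannot be ranked. The next compound, compound 3, `CCOC(=O)c1cnc(-c2ccc(C(F)(F)F)cc2)nc1NN1C(=O)C=C(C)C1=O`, differs from compound 2 in one place: trifluoromethyl in place of fluoro on an aromatic carbon. Among the compounds with values here, no measured step exchanges a fluoro for a trifluoromethyl, so nothing bears on this change directly. Within the data shown here, the single step known, a 1.3-fold lower number from compound 1 to compound 2 (0.11 log units; within the scatter), alters the same aromatic carbon and stays within the scatter, which gives no hint of sensitivity at that position. On this basis a step of no change at the digits printed from compound 2 to compound 3 (within the scatter) is expected for compound 3, that is, none beyond the scatter. Compound 3 is therefore estimated at 700 nM in this assay, with a range from 250 nM to 2000 nM.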

Compound 3, half-maximal inhibitory concentration: 400 nM
The estimate for compound 3 lay 1.8-fold (0.24 log units) above the measured number, and the stated range covers the measured number.
By their numbers in this assay, from the lowest: compounds 3, 2 and 1 (each within the scatter of the next, the first and the last beyond it).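

In this assay, trifluoromethyl in place of fluoro gives a 1.8-fold lower number from compound 2 to compound 3 (0.24 log units; within the scatter), so a group of 4 heavy atoms can stand on this aromatic carbon without a step that can be told from the scatter. Within the data shown here, the position is nevertheless not wholly insensitive: a 2.3-fold lower number from compound 1 to compound 3 (0.35 log units; beyond the scatter) is the first step at this carbon to pass beyond the scatter, although it is a modest one, and it comes from exchanging methoxy for trifluoromethyl. Nothing available here accounts for this step.

The compounds shown leave open whether an amine or a carboxylic acid on this same carbon would keep the number in this range. They also leave open whether the step from methoxy to trifluoromethyl would recur with a change elsewhere on the shared core.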